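The source may report more compounds than this note shows. Statements on the series, on what has been measured and on what is new or still open speak of the compounds shown alone.

Compound 1 `O=C(/C=C/c1ccc(Oc2ccccc2)cc1)c1ccc(F)cc1`: 33000 nM
Compound 2 `CCCCOc1ccc(C(=O)/C=C/c2c(OC)cccc2OC)cc1`: 127000 nM

In a functional assay (Homo sapiens) for inhibition (on this read-out lower numbers stand for stronger inhibition and higher numbers for weaker inhibition), compound 2 has the higher number of the two, and its gap to compound 1 lies beyond the scatter. Compound 3 `C=CCOc1ccc(C(=O)/C=C/c2c(OC)cccc2OC)cc1` differs from compound 2 in one place: vinyl in place of propyl on a saturated chain carbon bound to an oxygen on an aromatic ring. This turns butoxy into allyloxy. For the measured compounds named here, no measured pair shows this change, so in this assay only a small step is expected, in no firm direction and within the scatter. The expected step is a 1.3-fold lower number from compound 2 to compound 3 (0.10 log units; within the scatter). For compound 3 the estimated value is 100000 nM, with an expected range from 40000 nM to 250000 nM.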

Compound 3, half-maximal inhibitory concentration: 96000 nM
The estimate for compound 3 lay 1.0-fold (0.02 log units) above the measured number; the measured number falls inside the stated range.
By their numbers in this assay, from the lowest: compound 1; then compounds 3 and 2 (each within the scatter of the next).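

In this assay, vinyl in place of propyl on a saturated chain carbon bound to an oxygen on an aromatic ring gives a 1.3-fold lower number from compound 2 to compound 3 (0.12 log units; within the scatter), so this pair does not separate butoxy from allyloxy. At this position, the double bond outside aromatic rings that comes with allyloxy leaves no readable mark on the number. No measurement at hand offers a cause for this result.

As far as these compounds go, whether a longer chain or a terminal amine at this position would shift the number beyond the scatter remains open. So does whether a carboxylic acid there would do so.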